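Extending the Ether Chain on a Shared Core

A few compounds are considered here, and "the series" means these few. Any claim that something is new, unique, unknown or untested is made for them only; others in the source may bear on it.

Compound 3, `CCCCNc1nc(N)nnc1OC`, carries the shortest side chain among the three measured compounds. In an assay on isolated protein for agonist activity at Toll-like receptor 8 (Homo sapiens) (on this read-out lower numbers stand for an effect already at smaller amounts and higher numbers for an effect only at larger amounts of compound), compound 3 gives 2040 nM, the highest number of the set. Compound 1, `CCCCNc1nc(N)nnc1OCc1ccccc1F`, gives 560 nM in this assay, and compound 2, `CCCCNc1nc(N)nnc1OCCCN(C)C`, gives 100 nM. Both measured steps that bear on this position run toward compound 3 and raise the number: a 3.6-fold higher number from compound 1 to compound 3 (0.56 log units; beyond the scatter), and the larger 20-fold higher number from compound 2 to compound 3 (1.31 log units; beyond the scatter). Read in reverse, attaching a larger group to this chain carbon has so far lowered the number each time, with a chain carrying a nitrogen doing so most strongly.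

Compound 4, `CCCCNc1nc(N)nnc1OCCOC`, differs from compound 3 by methoxymethyl in place of hydrogen on a saturated chain carbon bound to an oxygen on an aromatic ring. The group entering is small and uncharged, so the step from this change is expected to be smaller than either measured one while keeping the same lowering direction, estimated as a 2.3-fold lower number from compound 3 to compound 4 (0.36 log units; beyond the scatter). Compound 4 is therefore estimated at 900 nM, with a likely range from 300 nM to 2700 nM.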

Compound 4, half-maximal effective concentration: 1000 nM
Compound 4: middle estimate off by 1.1-fold (0.05 log units), on the low side, within the range that was stated.
By their numbers in this assay, from the lowest: compound 2; then compounds 1 and 4 (each within the scatter of the next); then compound 3.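

In this assay methoxymethyl, with no ring and no net charge, still gives a 2.0-fold lower number from compound 3 to compound 4 (0.31 log units; beyond the scatter) at this chain carbon, so among these compounds neither a ring nor a nitrogen is needed for a lower number. Methoxymethyl in place of 2-fluorophenyl gives a 1.8-fold higher number from compound 1 to compound 4 (0.25 log units; within the scatter) and so no readable change, whereas methoxy in place of (dimethylamino)methyl gives a 10-fold higher number from compound 2 to compound 4 (1.00 log units; beyond the scatter) and shows that an ether chain alone does not reach the number of compound 2. Nothing available here explains these differences.

From the compounds shown here alone, how much depends on the dimethylamino group itself stays open. An amine without methyl groups, a carboxylic acid at the chain end, or a longer chain ending in methoxy would each help to separate the role of the end group from that of chain length.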